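A few compounds are considered here, and "the series" means these few. Any claim that something is new, unique, unknown or untested is made for them only; others in the source may bear on it.

Compound 1 `O=C(O)c1cnc(-c2ccccc2Cl)[nH]c1=O`: 5 mg/kg
Compound 2 `O=C(O)c1cnc(-c2ccccc2[N+](=O)[O-])[nH]c1=O`: > 50 mg/kg
Compound 3 `CCOC(=O)c1cnc(-c2ccccc2[N+](=O)[O-])[nH]c1=O`: "not determined" (no result reported)

In a functional assay on the whole organism (strain Sprague-Dawley) for inhibition, with Rattus norvegicus as the target, with a stated time of 10 min (on this read-out higher numbers stand for an effect only at larger amounts of compound and lower numbers for an effect already at smaller amounts), compound 1 gives 5 mg/kg. For compound 2 only a limit of this assay is reported, > 50 mg/kg; this is the limit of > 50 mg/kg in this assay, at which 1 of the 3 values shown sits. The step of an at least 10-fold higher number from compound 1 to compound 2 (1.00 log units; beyond the scatter) therefore reaches beyond the scatter. Compound 3 has no number in this assay, so it cannot be placed against compounds 1 and 2 on the numbers shown.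

Compound 4 `CCOC(=O)c1cnc(-c2ccccc2OCc2ccccc2)[nH]c1=O` differs from compound 3 by benzyloxy in place of nitro on an aromatic carbon. For the measured compounds named here, no measured step follows this change, and the only step known, from compound 1 to compound 2, concerns a different group, so the direction for compound 4 cannot be taken from it. Compound 4 is estimated to give 15 mg/kg in this assay, within a wide range from 3 mg/kg to 60 mg/kg.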

Compound 4, dose for 50% inhibition: > 5 mg/kg
Compound 4: no number, only a limit; the forecaster's own chance of this, stated with the estimate: 35%; the middle value lies beyond the limit too.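

No new step can be read between compound 3 and compound 4 in this assay. For compound 4 there is only a limit, > 5 mg/kg. The compounds shown leave open how benzyloxy compares with nitro on this read-out.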